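The compounds below may be only part of what the source reports. "The series", "measured", "known", "first", "only" and "open" are said of these compounds alone.

Among the measured compounds shown here, compound 3 `Cc1nc(C#Cc2cc(Br)cc(C#N)c2)cs1` gives 0.106 nM in an assay on HEK293 cells for displacement of a labelled ligand from metabotropic glutamate receptor 5 (Rattus norvegicus), read by scintillation counting (a higher number here means a weaker inhibitor, a lower number a stronger inhibitor), and stands at the low end of the three numbers so far, with compound 2 `Cc1nc(C#Cc2cc(Cl)cc(C#N)c2)cs1`, at 0.127 nM, within the scatter of it, while compound 1 `Cc1nc(C#Cc2cc(C#N)cc([N+](=O)[O-])c2)cs1` gives 0.36 nM in this assay. Of the measured steps, a 2.8-fold lower number from compound 1 to compound 2 (0.45 log units; beyond the scatter) and a 3.4-fold lower number from compound 1 to compound 3 (0.53 log units; beyond the scatter) are modest, whereas a 1.2-fold lower number from compound 2 to compound 3 (0.08 log units; within the scatter) stays within the scatter. Compound 4 `Cc1nc(C#Cc2cc(F)cc(Br)c2)cs1` arises from compound 3 by fluoro in place of cyano on an aromatic carbon. For the measured compounds named here, no measured step exchanges the cyano group, so the bearing of the nitro-for-chloro, nitro-for-bromo and chloro-for-bromo steps is indirect; a modest shift in this assay, more likely toward a higher number, is expected. Compound 4 is therefore estimated at 0.35 nM (range 0.1 nM to 1.2 nM), which would mean an expected 3.3-fold higher number from compound 3 to compound 4 (0.52 log units; beyond the scatter).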

Compound 4, inhibition constant: 1.06 nM
Estimate against measurement, compound 4: 3.0-fold (0.48 log units) below; the measured number falls inside the stated range.
By their numbers in this assay, from the lowest: compounds 3 and 2 (each within the scatter of the next); then compound 1; then compound 4.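

In this assay, among the compounds shown here, with the bromo group held, the cyano position is the first exchanged, and fluoro in place of cyano gives a 10-fold higher number from compound 3 to compound 4 (1.00 log units; beyond the scatter). This step is larger than any listed step exchanging nitro, chloro or bromo, so the cyano group is not interchangeable with fluoro in this pair. Nothing available accounts for the step. Open, as far as these compounds go, is whether an amine, a methoxy group or a carboxylic acid at this position would stay nearer compound 3. Also open, from the compounds shown here alone, is whether the step recurs with chloro in place of bromo.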